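Amino in place of chloro at the assay limit

A few compounds are considered here, and "the series" means these few. Any claim that something is new, unique, unknown or untested is made for them only; others in the source may bear on it.

In a functional assay on BJAB cells (Homo sapiens) for antiproliferative activity, read by CellTiter-Glo, with a stated time of 72 h (a higher number here means that more compound is needed for the effect, a lower number that less compound is needed), compound 2 (`O=C(Nc1cnc(-n2nccn2)c(Cl)c1)C1CCN(c2ncccc2Cl)CC1`) gives > 10000 nM as its result, which is a limit of the assay and not a number. Compound 1 (`Nc1cccnc1N1CCC(C(=O)Nc2ccc(-n3nccn3)c(Cl)c2)CC1`) gives > 10000 nM in this assay as its result, again a limit and not a number. For the measured compounds named here, compound 2 therefore stands level with the only other compound tested, and all there is to go on so far is the limit of > 10000 nM in this assay, at which 2 of the 2 values shown sit, as the common result.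

Compound 3 (`Nc1cccnc1N1CCC(C(=O)Nc2cnc(-n3nccn3)c(Cl)c2)CC1`) has not yet been measured. It differs from compound 2 in one place (amino in place of chloro on an aromatic carbon): amino in place of chloro on an aromatic carbon, ortho to a large group and two atoms from the ring nitrogen. The same difference reads 3-chloropyridin-2-yl to 3-aminopyridin-2-yl.

Going by the values given here, no measured step exists to lean on. The estimated step of a number no higher from compound 2 to compound 3 (the limit leaves the size open) is none beyond the usual scatter, with neither direction favoured. For compound 3 the expected value is 10000 nM in this assay, with an estimated range from 3000 nM to 30000 nM for any number reported.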

Compound 3, half-maximal effective concentration: > 10000 nM
Compound 3: no number, only a limit (the forecaster's own chance of this, stated with the estimate: 80%); the middle value lies on the limit itself.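

In this assay compound 3 gives > 10000 nM, a limit of the assay and not a number. Compound 2 also gives a limit, so no step can be read between compound 2 and compound 3. None of the compounds shown gives a number, and how amino compares with chloro at this place remains open.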